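A few compounds are considered here, and "the series" means these few. Any claim that something is new, unique, unknown or untested is made for them only; others in the source may bear on it.

In a functional assay on SW-620 cells (Homo sapiens) for antiproliferative activity, read by MTT assay, with a stated time of 72 h (a higher number here means a weaker inhibitor, a lower number a stronger inhibitor), compound 1 `O=C1NC(O)(CCn2cnc3cc[nH]c3c2=O)C(OCc2ccccc2)=C1OCc1ccccc1` gives 90700 nM, the only plain number among the two results shown, and it is a weak one. In this assay compound 2 `O=C1O/C(=C\Cn2cnc3ccnc(Cl)c32)C(OCc2ccccc2)=C1OCc1ccccc1` gives > 100000 nM, which is reported not as a number but as a limit. That value is the limit of > 100000 nM in this assay, at which 1 of the 2 values shown sits. Compound 3 `Nc1nc(F)c(Cl)c2c1ncn2CCC1(O)NC(=O)C(OCc2ccccc2)=C1OCc1ccccc1` is not yet measured; it differs from compound 1 by a group of 12 heavy atoms (6 carbon, 4 nitrogen, 1 fluorine, 1 chlorine; one five-membered aromatic ring with 2 hetero atoms, one six-membered aromatic ring with 1 hetero atom) in place of a group of 10 heavy atoms (6 carbon, 3 nitrogen, 1 oxygen; one five-membered aromatic ring with 1 hetero atom, one six-membered aromatic ring with 2 hetero atoms), on a saturated chain carbon, two bonds along the chain from a saturated ring carbon. Among the measured compounds shown here, no step between measured compounds is available to guide the direction, so the expected step is a 1.1-fold lower number from compound 1 to compound 3 (0.05 log units; within the scatter), none beyond the scatter. Compound 3 is therefore estimated at 80000 nM, between 30000 nM and 160000 nM.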

Compound 3, half-maximal inhibitory concentration: 59000 nM
The estimate for compound 3 lay 1.4-fold (0.13 log units) above the measured number, and the stated range covers the measured number.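

In this assay, placing the group of 12 heavy atoms, with its fluorine and chlorine, on the saturated chain carbon in place of the group of 10 heavy atoms gives a 1.5-fold lower number from compound 1 to compound 3 (0.19 log units; within the scatter). This position therefore accepts an exchange of both aromatic rings with no change beyond the scatter, and compound 3 remains a plain number. Compound 2 is reported as a limit, not a number: the limit of > 100000 nM in this assay, at which 1 of the 3 values shown sits.

Among the compounds shown here, the single step exchanges the whole group, so it cannot separate the share of the fluorine from that of the chlorine. Going by these compounds, whether a carboxylic acid or a longer chain at this place would give a clearly lower number stays open.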